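Moving the Bromine Around the Phenyl Ring

The source may hold more compounds than are shown below. What is called first, only, known or untested is meant among the compounds shown, and "the series" means these compounds.

Compound 1 `COc1ccc(/C=C2\CCC/C(=C\c3ccccc3Br)C2=O)cc1OC` gives 8400 nM
Compound 2 `COc1ccc(/C=C2\CCC/C(=C\c3cccc(Br)c3)C2=O)cc1OC` gives 5200 nM

Both numbers come from a functional assay on HT-1080 cells (Homo sapiens) for cytotoxicity, read by MTT assay, with a stated time of 72 h; on this read-out lower numbers stand for stronger inhibition and higher numbers for weaker inhibition. Compound 2, at 5200 nM, lies within the usual scatter of compound 1, so the two cannot be ranked.

Compound 3 `COc1ccc(/C=C2\CCC/C(=C\c3ccc(Br)cc3)C2=O)cc1OC` has not yet been measured. It differs from compound 2 in one place: 4-bromophenyl in place of 3-bromophenyl on a double-bonded chain carbon bound to a double-bonded ring carbon. In words, it carries 4-bromophenyl in place of 3-bromophenyl on a double-bonded chain carbon bound to a double-bonded ring carbon.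

Among the compounds with values here, only one measured step bears on this: a 1.6-fold lower number from compound 1 to compound 2 (0.21 log units; within the scatter). That swap is of a similar kind, putting 3-bromophenyl in place of 2-bromophenyl, and it stays within the scatter. Within the data shown here, a single step is thin evidence, and no measured compound carries 4-bromophenyl. Even so, no step beyond the scatter is expected in this assay, and the data suggest no direction. The expected change is a 1.1-fold higher number from compound 2 to compound 3 (0.02 log units; within the scatter). The estimated value for compound 3 is 5500 nM, with an expected range from 2600 nM to 11000 nM.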

Compound 3, half-maximal inhibitory concentration: 4300 nM
The estimate for compound 3 lay 1.3-fold (0.11 log units) above the measured number; the measured number falls inside the stated range.
By their numbers in this assay, from the lowest: compounds 3, 2 and 1 (each within the scatter of the next).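

With compound 3 added, all three bromine placements, 2-bromophenyl, 3-bromophenyl and 4-bromophenyl, can be compared in this assay: the new step gives a 1.2-fold lower number from compound 2 to compound 3 (0.08 log units; within the scatter), and the widest pair gives a 2.0-fold lower number from compound 1 to compound 3 (0.29 log units; within the scatter). Even that widest pair stays inside the scatter, so the three compounds cannot be ranked, and these data give no sign that the bromine's placement on this phenyl ring matters for the measured number. No measurement of any property of these groups accompanies the numbers, so nothing here can explain how they relate.

Every compound shown keeps a bromophenyl group on the double-bonded chain carbon, so it remains open whether a different substituent on that phenyl ring, such as an amine or a carboxylic acid, would move the number beyond the scatter. The rest of the shared core is also identical across all three compounds, so these results say nothing about how changes elsewhere in the structure would register in the same cell test.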